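A few compounds are considered here, and "the series" means these few. Any claim that something is new, unique, unknown or untested is made for them only; others in the source may bear on it.

Measured compounds:

compound 1, `COc1ccc(-n2c(=O)c(C(=O)Nc3ccc(Oc4ccnc5[nH]ccc45)c(F)c3)cc3cccnc32)cc1`: in a functional assay on HT-29 cells (Homo sapiens) for antiproliferative activity, read by MTT assay, with a stated time of 72 h (on this read-out lower numbers stand for stronger inhibition and higher numbers for weaker inhibition), compound 1 gives 540 nM
compound 2, `O=C(Nc1ccc(Oc2ccnc3[nH]ccc23)c(F)c1)c1cc2cccnc2n(-c2ccc(F)c(Cl)c2)c1=O`: in this assay compound 2 gives 310 nM
compound 3, `COc1ccc(-n2c(=O)c(C(=O)Nc3ccc(Oc4ccnc5c4ccn5C)cc3)cc3cccnc32)cc1`: in this assay compound 3 gives 2050 nM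

Compound 1 and compound 2 share one core and differ only in the group on the aromatic nitrogen; the change is 3-chloro-4-fluorophenyl in place of 4-methoxyphenyl on an aromatic nitrogen and it made a 1.7-fold lower number from compound 1 to compound 2 (0.24 log units; within the scatter). Compound 3 carries a different core; how its core differs from that of compound 1 is not broken down here. What the values show is that compound 3 stands highest of the three, beyond the scatter from both compound 1 and compound 2.

Compound 4, `Cn1ccc2c(Oc3ccc(NC(=O)c4cc5cccnc5n(-c5ccc(F)c(Cl)c5)c4=O)cc3)ccnc21`, is not yet measured. It is made from compound 3 by 3-chloro-4-fluorophenyl in place of 4-methoxyphenyl on an aromatic nitrogen, the same change as that from compound 1 to compound 2, at a place described in the same words. On the core of compound 1 this change gave a step within the scatter, so a step of similar size is expected here: the step from compound 3 to compound 4 in this assay is estimated as a 1.7-fold lower number from compound 3 to compound 4 (0.23 log units; within the scatter), resting on a 1.7-fold lower number from compound 1 to compound 2 (0.24 log units; within the scatter). Compound 4 is therefore expected to give about 1200 nM in this assay, with an estimated range from 550 nM to 2600 nM.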

Compound 4, half-maximal inhibitory concentration: 1210 nM
Beside the measured number, compound 4's estimate is 1.0-fold (0.00 log units) below it; the range from low to high includes it.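

In this assay, putting 3-chloro-4-fluorophenyl in place of 4-methoxyphenyl on the aromatic nitrogen gives a 1.7-fold lower number from compound 3 to compound 4 (0.23 log units; within the scatter), and the step matches the one seen on the other core: the same change on two cores in this assay, a 1.7-fold lower number (0.24 log units; within the scatter) from compound 1 to compound 2 and a 1.7-fold lower number (0.23 log units; within the scatter) from compound 3 to compound 4, 1.0-fold (0.01 log units) apart, within the scatter of two such steps
The change therefore behaves alike on these two cores, and the core of compound 3 gives no sign of altering its outcome. Each step lies within the scatter on its own, however, so the pair does not establish that the change has any real effect on this read-out, and two cores cannot show that the match would hold on a third.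

The compounds shown leave open whether a different group on the aromatic nitrogen, such as an amine-bearing chain, a carboxylic acid or a plain alkyl chain, would give a step beyond the scatter. They also leave open which part of the difference between the core of compound 1 and the core of compound 3 goes with the higher numbers on the latter.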